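The source may hold more compounds than are shown below. What is called first, only, known or untested is meant among the compounds shown, and "the series" means these compounds.

Working notes on the series.

Two compounds carry numbers in an assay on LNCaP cells for inhibition of RAC-alpha serine/threonine-protein kinase (Homo sapiens); a higher number here means a weaker inhibitor, a lower number a stronger inhibitor. Compound 1 `CCOCCN(C[C@@H](O)CN1CCC2(CCN(c3ncnc4[nH]nc(C)c34)C2)C1)S(=O)(=O)c1c(C)cccc1C` gives 3100 nM in this assay. Compound 2 `Nc1ncnc(N2CC[C@@]3(CCCN(C[C@H](O)CNS(=O)(=O)c4ccccc4F)C3)C2)c1C1CC1` gives 14000 nM in this assay, the highest of the two numbers; the gap to compound 1, whose number is lower, lies beyond the usual scatter of repeated measurements. For the measured compounds named here, no pair of measured compounds differs in a single place, so no measured step is available for any structural change.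

Compound 3 `Cc1noc(C)c1S(=O)(=O)NC[C@@H](O)CN1CCC[C@@]2(CCN(c3ncnc(N)c3C3CC3)C2)C1` has not been measured. It differs from compound 2 in one place: 3,5-dimethyl-1,2-oxazol-4-yl in place of 2-fluorophenyl on a sulfonyl sulfur. The rest of the molecule, including the shared core of compound 2 and the hydroxy-bearing linker, is unchanged. Nothing in the measured pair speaks to a swap of the aryl group on the sulfonyl sulfur, so there is no basis for expecting a step beyond the scatter in either direction. The estimate for compound 3 therefore stays close to compound 2, with a step from compound 2 to compound 3 of a 1.2-fold lower number from compound 2 to compound 3 (0.07 log units; within the scatter) expected in this assay. Compound 3 is estimated at 12000 nM in this assay, within a range from 4000 nM to 36000 nM.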

Compound 3, half-maximal inhibitory concentration: 490 nM
The estimate for compound 3 lay 24-fold (1.39 log units) above the measured number; the whole stated range lies above it.
By their numbers in this assay, from the lowest: compound 3; then compound 1; then compound 2.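

The aryl group on the sulfonyl sulfur is now shown to be a place where the number in this assay responds strongly: 3,5-dimethyl-1,2-oxazol-4-yl in place of 2-fluorophenyl gives a 29-fold lower number from compound 2 to compound 3 (1.46 log units; beyond the scatter), with the rest of the molecule unchanged. Both groups have 7 heavy atoms and no net charge, so the step comes with no change in those counts, but with a five-membered aromatic ring with 2 hetero atoms replacing a six-membered aromatic ring of carbon only, and with 2 hydrogen-bond acceptors entering where the leaving group has 0. No measurement bears on which of these differences accounts for the step.

As far as these compounds go, it stays open whether the step follows the ring hetero atoms, the two methyl groups or the loss of the fluorine, a question that a plain phenyl, an unsubstituted 1,2-oxazol-4-yl or a pyridyl on the sulfonyl sulfur could help to separate. From the compounds shown here alone, it also stays open whether the same swap would give a step of similar size on the core of compound 1.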